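A few compounds are considered here, and "the series" means these few. Any claim that something is new, unique, unknown or untested is made for them only; others in the source may bear on it.

Of the compounds shown here, three built on the shared core have been measured in a functional assay on A549 cells (Homo sapiens) for antiproliferative activity, read by MTT assay, with a stated time of 72 h; a lower number here means a stronger inhibitor, a higher number a weaker inhibitor. Compound 1 `N[C@H]1CCc2nc(-c3ccncc3)nc(Nc3cccc(F)c3)c2C1` gives 23300 nM, and compound 3 `N[C@@H]1CCc2nc(-c3ccncc3)nc(Nc3cccc(F)c3)c2C1`, which carries the same atoms and bonds, gives 17800 nM. Going by the values given here, the step of a 1.3-fold lower number from compound 1 to compound 3 (0.12 log units; within the scatter) is the only one between two measured compounds, and it rests on (the fact that compounds 1 and 3 differ only in the configuration as drawn). Compound 2 `CN(C)c1ccc(Nc2nc(-c3ccncc3)nc3c2CC(N)CC3)cc1` gives 17100 nM, the lowest of the three numbers, though its gaps to compound 3 and to compound 1 both lie within the scatter, so no order among the three compounds can be read from these values.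

Compound 4 `COc1cccc(Nc2nc(-c3ccncc3)nc3c2CC(N)CC3)c1` differs from compound 2 in one place: 3-methoxyphenyl in place of 4-(dimethylamino)phenyl on a nitrogen on an aromatic ring. Among the compounds with values here, no measured step alters the group on that nitrogen; the single step from compound 1 to compound 3 concerns only a configuration at a saturated ring carbon and so offers no guide to the size or direction of this change. Since the three measured values all fall close to one another, compound 4 is expected to remain in that region, and the step of a 1.2-fold higher number from compound 2 to compound 4 (0.07 log units; within the scatter) is expected to stay within the scatter. In this assay compound 4 is therefore estimated to give 20000 nM, with a range from 8000 nM to 50000 nM.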

Compound 4, half-maximal inhibitory concentration: 18000 nM
For compound 4 the middle estimate is 1.1-fold (0.05 log units) above the measured one; low and high end bracket the measured number.
By their numbers in this assay, from the lowest: compounds 2, 3, 4 and 1 (each within the scatter of the next).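

In this assay, putting 3-methoxyphenyl in place of 4-(dimethylamino)phenyl on a nitrogen on an aromatic ring gives a 1.1-fold higher number from compound 2 to compound 4 (0.02 log units; within the scatter). Going by these compounds alone, this is the first measured step that alters the group at this place, since the earlier step concerned only a configuration at a saturated ring carbon, and it shows that these two groups cannot be told apart in this read-out. The leaving group carries nitrogen and the entering group carries oxygen, yet the two compounds remain within the scatter of each other, and no available evidence speaks to this exchange.

As far as these compounds go, what remains open is whether any group on this nitrogen can move the number beyond the scatter, for instance a phenyl ring carrying a carboxylic acid or a primary amine, or a longer alkyl chain in place of the aromatic ring. Also open is how the amine on the saturated ring carbon contributes, since neither replacing it with a hydroxyl or an acetamide nor a defined configuration in compound 2 or compound 4 is covered by the compounds shown.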